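Working notes: aromatic substituent changes and maximal response

This account rests on a few compounds, and the source may have more. Where it says the series, first, only, none or still open, it means among the compounds named here.

Measured compounds:
- compound 1 `CC(Oc1ccccc1C=O)C1=NCCN1`: 0.5
- compound 2 `CC(C)Oc1ccccc1OC(C)C1=NCCN1`: 0.5
- compound 3 `C=COc1ccccc1OC(C)C1=NCCN1`: 0.45

In an assay on CHO cells with Alpha-2B adrenergic receptor (Homo sapiens) as the target (a higher number here means a larger maximal response, a lower number a smaller maximal response), compound 1 gives 0.5, level with compound 2 at the digits shown; together these are the highest of the three numbers. Compound 3 gives 0.45. The steps of no change at the digits printed from compound 1 to compound 2 (within the scatter) and a number 0.050 lower from compound 1 to compound 3 (within the scatter) both stay within the scatter, as does a number 0.050 lower from compound 2 to compound 3 (within the scatter), so across the three substituents tried on this aromatic carbon the maximal response has not moved beyond noise.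

Compound 4 `C=C(C)c1ccccc1OC(C)C1=NCCN1` has not been measured. It differs from compound 1 as follows: 1-methylethenyl in place of formyl on an aromatic carbon. The steps bearing on this change are no change at the digits printed from compound 1 to compound 2 (within the scatter) and a number 0.050 lower from compound 1 to compound 3 (within the scatter), each within the scatter, which shows that the formyl group can be exchanged for groups of different size without a visible shift. Going by the values given here, none of the measured groups, however, lacks a hydrogen-bond acceptor as 1-methylethenyl does, so the range is kept wider than the measured spread.

The step a number 0.020 lower from compound 1 to compound 4 (within the scatter) is therefore expected to be none beyond the scatter. For compound 4 the estimate is 0.48, with a range from 0.33 to 0.62.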

Compound 4, intrinsic activity: the largest response reached, as a fraction of the reference agonist's: 0.4
Compound 4: middle estimate off by 0.080, on the high side; the range from low to high includes it.
By their numbers in this assay, from the lowest: compounds 4, 3, 1 and 2 (each within the scatter of the next).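

Working notes: in this assay, 1-methylethenyl is the only group shown on this aromatic carbon that has no hydrogen-bond acceptor and no oxygen, yet the steps are a number 0.10 lower from compound 1 to compound 4 (within the scatter), a number 0.10 lower from compound 2 to compound 4 (within the scatter) and a number 0.050 lower from compound 3 to compound 4 (within the scatter). Removing the acceptor count of formyl and adding one heavy atom therefore gives no step beyond the scatter, so the earlier flat reading across formyl, isopropoxy and vinyloxy now extends to an all-carbon group, and none of the four groups can be ranked on maximal response. No measurement at hand accounts for these numbers or says what, if anything, the position contributes to the response.

Still open, from the compounds shown here alone, is whether a group of another kind on this aromatic carbon, such as an amine, a carboxylic acid or a longer alkyl chain, would give a step beyond the scatter. The compounds shown also leave open whether the same indifference holds for the same groups on other carbons of the aromatic ring, and whether it extends to read-outs other than maximal response.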